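Bromo to Iodo on the Thiourea Phenyl Ring

This account rests on a few compounds, and the source may have more. Where it says the series, first, only, none or still open, it means among the compounds named here.

Compound 1, `N#Cc1c(-c2ccc(Br)cc2)cn(-c2ccc(S(N)(=O)=O)cc2)c1NC(=S)Nc1ccccc1`, gives 7.29 nM in a functional assay on MCF7 cells (Homo sapiens) for cytotoxicity, read by sulforhodamine B assay, with a stated time of 48 h; a lower number here means a stronger inhibitor, a higher number a weaker inhibitor.
Compound 2, `N#Cc1c(-c2ccc(Br)cc2)cn(-c2ccc(S(N)(=O)=O)cc2)c1NC(=S)Nc1ccc(Br)cc1`, gives 8.15 nM in this assay.

Among the compounds with values here, only two compounds have numbers so far, and the single measured step between them, a 1.1-fold higher number from compound 1 to compound 2 (0.05 log units; within the scatter), is within the scatter. Compound 2 therefore stands level with compound 1 rather than apart from it; the two values cannot be told apart by this assay.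

Compound 3, `N#Cc1c(-c2ccc(Br)cc2)cn(-c2ccc(S(N)(=O)=O)cc2)c1NC(=S)Nc1ccc(I)cc1`, is not yet measured. It differs from compound 2 in one place: iodo in place of bromo on an aromatic carbon. Within the data shown here, the one step that bears on this change is the one in which bromo entered that same position, and its size, a 1.1-fold higher number from compound 1 to compound 2 (0.05 log units; within the scatter), was small. Exchanging one halogen for another at a position where adding a halogen made no difference beyond the scatter gives no reason to expect a large move in this assay in either direction.

Compound 3 is therefore expected to give about 8.5 nM, with a likely range from 4.2 nM to 17 nM. That estimate corresponds to a step of a 1.0-fold higher number from compound 2 to compound 3 (0.02 log units; within the scatter), which stays within the scatter.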

Compound 3, half-maximal inhibitory concentration: 8.15 nM
The estimate for compound 3 lay 1.0-fold (0.02 log units) above the measured number, and the stated range covers the measured number.
By their numbers in this assay, from the lowest: compounds 1, 2 and 3 (each within the scatter of the next).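

Exchanging the 4-bromophenyl for a 4-iodophenyl on the thiourea gives, in this assay, no change at the digits printed from compound 2 to compound 3 (within the scatter), and putting iodo in place of hydrogen at that same place gives a 1.1-fold higher number from compound 1 to compound 3 (0.05 log units; within the scatter). Compound 2 alone could not show whether the flat result belonged to bromo in particular; with compound 3 there are now two different halogens at this place, and neither can be told apart from hydrogen in this assay. For these three compounds, then, the identity of the atom on this aromatic carbon makes no difference that the measurement can detect.

Hydrogen, bromo and iodo are a narrow sample of what could sit there, so it remains open whether a group of another kind at the same place, such as an amine, a carboxylic acid or a longer chain, would leave the number just as level or shift it clearly beyond the scatter. Nothing measured in the data shown speaks to why these three compounds read alike.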